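The source may report more compounds than this note shows. Statements on the series, on what has been measured and on what is new or still open speak of the compounds shown alone.

Cytotoxicity in the series is followed with an ADME assay on Vero cells (Chlorocebus sabaeus) for cytotoxicity; a higher number here means that more compound is tolerated, a lower number that less compound is tolerated. Compound 2 `CCCc1cc(-c2cn([C@H]3C[C@H](OC(C)=O)[C@@H](COC(C)=O)O3)c(=O)[nH]c2=O)on1` gives 3000 nM in that assay. Compound 1 `CCCCCCCCc1cc(-c2cn([C@H]3C[C@H](O)[C@@H](CO)O3)c(=O)[nH]c2=O)on1` gives 3000 nM, and compound 3 `CC(=O)OC[C@H]1O[C@@H](n2cc(-c3cc(-c4ccc(C(C)(C)C)cc4)no3)c(=O)[nH]c2=O)C[C@@H]1OC(C)=O` gives 3000 nM. Compound 2 is thus level with both compounds at the digits shown, within the scatter, with compound 1 nearest and compound 3 furthest, though neither gap exceeds the scatter. Among the compounds with values here, the only single-point step measured so far is no change at the digits printed from compound 2 to compound 3 (within the scatter), a change of 4-(tert-butyl)phenyl in place of propyl on an aromatic carbon.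

Compound 4 `CC(=O)OC[C@H]1O[C@@H](n2cc(-c3cc(-c4ccc(C(C)C)cc4)no3)c(=O)[nH]c2=O)C[C@@H]1OC(C)=O` is not yet measured. It differs from compound 2 as follows: 4-isopropylphenyl in place of propyl on an aromatic carbon. The step from compound 2 to compound 3 is the direct comparison, since the same propyl is replaced at the same place by a closely related para-substituted phenyl, and that step stayed within the scatter. Compound 1, which differs from compound 2 in more than one place, sits at the same level as well. Within the data shown here, no step so far moves this assay beyond the scatter. For compound 4 no change beyond the scatter is expected, with the expected step being no change at the digits printed from compound 2 to compound 4 (within the scatter). Compound 4 is therefore estimated at 3000 nM, with a range from 1500 nM to 6000 nM.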

Compound 4, half-maximal cytotoxic concentration: 3000 nM
Estimate against measurement, compound 4: no gap at the digits printed, within the range that was stated.
By their numbers in this assay, from the lowest: compounds 1, 2, 3 and 4 (each within the scatter of the next).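

In this assay, 4-isopropylphenyl on this aromatic carbon of the five-membered ring gives no change at the digits printed from compound 2 to compound 4 (within the scatter), so a second substituted phenyl now reads the same as propyl here, and the result no longer rests on 4-(tert-butyl)phenyl alone. Hydrogen in place of methyl on the saturated chain carbon bound to the aromatic carbon gives no change at the digits printed from compound 3 to compound 4 (within the scatter), so the read at this position also stays the same when the branched end of the phenyl substituent is trimmed. Nothing available accounts for this flat read.

As far as these compounds go, whether an amine or a carboxylic acid on the phenyl ring in place of isopropyl would move the read remains open. From the compounds shown here alone, the role of the two acetate esters also remains open, since compound 1 differs from compound 2 in more than one place.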